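Formyl for ethyl on the aryl arm of compound 3

The source may hold more compounds than are shown below. What is called first, only, known or untested is meant among the compounds shown, and "the series" means these compounds.

Within the data shown here, compound 3 `CCc1ccc(-c2cn3ccnc3c(-c3ccc4ncn(Cc5ccccc5)c4c3)n2)cc1` gives 23% in a functional assay on NCI-H23 cells (Homo sapiens) for inhibition, read by sulforhodamine B assay, with a stated time of 48 h, tested at 10 uM (a higher number here means more inhibition at the concentration tested (going by the name of the read-out), a lower number less inhibition), the highest of the three numbers measured so far. Compound 2 `Fc1ccccc1-c1cn2ccnc2c(-c2ccc3ncn(C4CCCCC4)c3c2)n1` gives 4.16% and compound 1 `Clc1ccc(-c2cn3ccnc3c(-c3ccc4ncn(C5CCCCC5)c4c3)n2)cc1` gives 4.11%, both lying beyond the scatter below compound 3. Among the measured compounds shown here, the one step between measured neighbours, a number 0.1 percentage points higher from compound 1 to compound 2 (within the scatter), concerns a different group and does not bear on the change considered here. Compound 4 `O=Cc1ccc(-c2cn3ccnc3c(-c3ccc4ncn(Cc5ccccc5)c4c3)n2)cc1` differs from compound 3 by formyl in place of ethyl on an aromatic carbon. For the measured compounds named here, no measured step covers a formyl entering for an ethyl, so the series gives no direction for this change. The step expected here, a number 5 percentage points lower from compound 3 to compound 4 (within the scatter), is therefore taken as small, with wide uncertainty. Compound 4 is estimated at 18%, within 0% to 40%.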

Compound 4, a percentage reported as inhibition, at one concentration (the size of the read-out at that concentration, not a potency): 54.5%
Estimate against measurement, compound 4: 36.5 percentage points below; the measured number lies above the stated range.
By their numbers in this assay, from the lowest: compounds 1 and 2 (each within the scatter of the next); then compound 3; then compound 4.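

In this assay, the aromatic carbon para to a large group proves sensitive to the group it carries: a number 31.5 percentage points higher from compound 3 to compound 4 (beyond the scatter) is a large step. Ethyl and formyl have the same count of heavy atoms, so this step comes with no change in that count, while formyl brings a hydrogen-bond acceptor. No measured property of these compounds accounts for the step.

The compounds shown leave open whether the carbonyl is what matters, which an acetyl, a hydroxymethyl or a carboxylic acid here would test. From the compounds shown here alone, whether formyl acts likewise on the core of compound 1 also remains open.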